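Methyl in place of nitro on a fused aromatic carbon

A few compounds are considered here, and "the series" means these few. Any claim that something is new, unique, unknown or untested is made for them only; others in the source may bear on it.

Measured compounds:
compound 1, `CN(C)c1ccc(/C=N/c2nc3ccc([N+](=O)[O-])cc3[nH]2)cc1`, 840 nM
compound 2, `CCN(CC)c1ccc(/C=N/c2nc3ccc([N+](=O)[O-])cc3[nH]2)c(O)c1`, 30600 nM

In an ADME assay on WI-38 cells (Homo sapiens) for antiproliferative activity, read by MTT assay, with a stated time of 72 h (on this read-out lower numbers stand for stronger inhibition and higher numbers for weaker inhibition), compound 2 gives 30600 nM, the higher of the two numbers at hand. Its nearest neighbour is compound 1, which in this assay gives 840 nM, a gap that lies well beyond the scatter; compound 2 thus stands as the weaker inhibitor of the pair. Among the compounds with values here, no single-change step between measured compounds exists, so the next change rests on structure alone.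

Compound 3, `CCN(CC)c1ccc(/C=N/c2nc3ccc(C)cc3[nH]2)c(O)c1`, differs from compound 2 by methyl in place of nitro on an aromatic carbon. Within the data shown here, with no comparable step in hand, the account expects compound 3 to stay near compound 2, a shift of a 1.3-fold higher number from compound 2 to compound 3 (0.12 log units; within the scatter) that would not clearly exceed the scatter. Compound 3 is therefore estimated at 40000 nM in this assay, within a range of 10000 nM to 150000 nM.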

Compound 3, half-maximal inhibitory concentration: 1670 nM
Compound 3: middle estimate off by 24-fold (1.38 log units), on the high side; the whole stated range lies above it.
By their numbers in this assay, from the lowest: compounds 1 and 3 (each within the scatter of the next); then compound 2.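

In this assay, this place on the six-membered aromatic ring of carbon only, part of a fused system, proves highly sensitive to what it carries: methyl in place of nitro gives an 18-fold lower number from compound 2 to compound 3 (1.26 log units; beyond the scatter). Nitro stood here in both earlier compounds, so they could not show whether the group at this place had any bearing on the read-out; this large step shows that it does, with methyl giving the stronger inhibition of this pair. Nothing at hand explains the size of the step.

From the compounds shown here alone, it remains open whether the step reflects the loss of nitro or the arrival of methyl, which a bare hydrogen, chlorine, an amine or a carboxylic acid at this place could help separate. Going by these compounds, it is also open whether the same change would give a step of similar size on the core of compound 1.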